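Allyl swapped for butyl in a small amide series

The compounds below may be only part of what the source reports. "The series", "measured", "known", "first", "only" and "open" are said of these compounds alone.

Measured so far in an ADME assay on DU-145 cells (Homo sapiens) for cytotoxicity, read by MTT assay, with a stated time of 72 h; on this read-out higher numbers stand for weaker inhibition of growth and lower numbers for stronger inhibition of growth:
- compound 1 `CCCCCCCCCCNC(=O)C1C(C(=O)O)[C@@H]2CC[C@H]1O2` gives 10000 nM
- compound 2 `C=CCNC(=O)C1C(C(=O)O)[C@@H]2CC[C@H]1O2` gives 10000 nM

Compound 2 stands level with compound 1 in this assay at the digits reported, with no change beyond the scatter. The next compound, compound 3 `CCCCNC(=O)C1C(C(=O)O)[C@@H]2CC[C@H]1O2`, has not yet been measured. It differs from compound 2 in one place propyl in place of vinyl on a saturated chain carbon bound to an amide-type nitrogen and carries propyl in place of vinyl on a saturated chain carbon bound to an amide-type nitrogen. Among the measured compounds shown here, no measured pair differs in just one place, so the only guide is that compound 1 at 10000 nM and compound 2 at 10000 nM show no gap although their chains differ. No step beyond the scatter is therefore expected in this assay, in either direction. The estimated step of no change at the digits printed from compound 2 to compound 3 (within the scatter) stays within the scatter. For compound 3 the estimated value is 10000 nM, with an expected range from 6000 nM to 13000 nM.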

Compound 3, concentration for 50% growth inhibition: 10000 nM
Compound 3: middle estimate and measured number agree at the digits printed; the measured number falls inside the stated range.
By their numbers in this assay, from the lowest: compounds 1, 2 and 3 (each within the scatter of the next).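

In this assay, propyl in place of vinyl on a saturated chain carbon bound to an amide-type nitrogen, which is allyl to butyl, gives no change at the digits printed from compound 2 to compound 3 (within the scatter), so this single-place comparison shows that losing the double bond does not separate the two compounds. Hydrogen in place of hexyl on a saturated chain carbon, four bonds along the chain from an amide-type nitrogen, gives no change at the digits printed from compound 1 to compound 3 (within the scatter), so this change in chain length also leaves the two compounds level. No measurement at hand explains these results.

All three compounds keep the shared core and carry plain carbon chains on the amide. Going by these compounds, whether an amine or a phenyl ring on that chain, or a methyl ester in place of the carboxylic acid, would give a different number remains open.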